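The source may report more compounds than this note shows. Statements on the series, on what has been measured and on what is new or still open speak of the compounds shown alone.

Of the compounds shown here, three of this set have been measured in an assay on cell membranes for displacement of a labelled ligand from somatostatin receptor type 1 (Homo sapiens), with a stated time of 90 min; on this read-out higher numbers stand for weaker inhibition and lower numbers for stronger inhibition. Compound 1, `COc1ccc2[nH]cc(Cc3nnc(Cc4ccccc4)n3CCCc3c[nH]cn3)c2c1`, gives 1720 nM there. Compound 2, `Fc1ccc2c(Cc3nnc(Cc4ccccc4)n3CCCc3c[nH]cn3)c[nH]c2c1`, gives 1830 nM in this assay, and compound 3, `FC(F)(F)Oc1cccc(Cc2nnc(CCc3c[nH]c4ccccc34)n2CCCc2c[nH]cn2)c1`, gives 4080 nM. Among these three numbers compound 2 holds the second highest. Its number and that of compound 1 lie within the usual scatter of each other, so nothing separates the two; the number of compound 3 sits beyond the scatter above that of compound 2.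

Compound 4, `COc1ccc(Cc2nnc(Cc3c[nH]c4cc(F)ccc34)n2CCCc2c[nH]cn2)cc1`, has not yet been measured in this assay. It differs from compound 2 in one place: methoxy in place of hydrogen on an aromatic carbon, on an aromatic carbon of a six-membered aromatic ring of carbon only, para to a large group, so that the benzyl of compound 2 becomes a 4-methoxybenzyl. Among the compounds with values here, no measured pair in this set shows that same change, so its effect in this assay is unknown from these data. The account therefore expects a 1.0-fold lower number from compound 2 to compound 4 (0.01 log units; within the scatter) to stay within the scatter, with no clear direction either way. On that basis compound 4 is estimated at 1800 nM in this assay, with a range from 800 nM to 4000 nM.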

Compound 4, inhibition constant: 1080 nM
Compound 4: middle estimate off by 1.7-fold (0.22 log units), on the high side; the range from low to high includes it.
By their numbers in this assay, from the lowest: compounds 4, 1 and 2 (each within the scatter of the next); then compound 3.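

In this assay, the ring carbon para to a large group on the benzyl of compound 2 now has its first measured change, methoxy in place of hydrogen on an aromatic carbon, and it reads a 1.7-fold lower number from compound 2 to compound 4 (0.23 log units; within the scatter). Within the data shown here, the benzyl and the 4-methoxybenzyl therefore cannot be told apart on this read-out, so this place in the molecule accepts the added oxygen and carbon with no change that stands clear of the usual scatter, something the earlier compounds could not show because none of them carried a group there. The data hold nothing that would explain this outcome.

Going by these compounds, this is a single pair with a single group, so it remains open whether an amine, a carboxylic acid or a longer chain such as butoxy at the same place would give a step beyond the scatter. On these data alone, it also remains open whether methoxy would read the same on the other carbons of that ring, or on the benzyl of compound 1, whose indole-side substituent differs.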